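This account rests on a few compounds, and the source may have more. Where it says the series, first, only, none or still open, it means among the compounds named here.

Measured so far in a functional assay on MDA-MB-231 cells (Homo sapiens) for antiproliferative activity, read by MTT assay, with a stated time of 48 h; on this read-out higher numbers stand for weaker inhibition of growth and lower numbers for stronger inhibition of growth:

- Compound 1 `CCOC(=O)N1N=C(c2cccc(OC)c2)CC1c1cc(OC)c(OC)c(OC)c1` gives 9100 nM
- Compound 2 `CCOC(=O)N1N=C(c2ccc(OC)cc2)CC1c1cc(OC)c(OC)c(OC)c1` gives 2660 nM
- Compound 3 `COC(=O)N1N=C(c2cccc(O)c2)CC1c1cc(OC)c(OC)c(OC)c1` gives 740 nM

Compound 3 has the lowest number of the three, so it inhibits growth most strongly in this set, and its gaps to compound 1 and compound 2 both lie beyond the scatter. The next compound, compound 4 `CCOC(=O)N1N=C(c2cccc(O)c2)CC1c1cc(OC)c(OC)c(OC)c1`, has not been measured yet. It differs from compound 3 in one place, where methoxycarbonyl becomes ethoxycarbonyl: methyl in place of hydrogen on a saturated chain carbon bound to an oxygen next to a carbonyl group. In words, this is methyl in place of hydrogen on a saturated chain carbon bound to an oxygen next to a carbonyl group.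

For the measured compounds named here, no measured step covers this change. Going by the values given here, the only single-place step, a 3.4-fold lower number from compound 1 to compound 2 (0.53 log units; beyond the scatter), swaps 3-methoxyphenyl for 4-methoxyphenyl and leaves the ethoxycarbonyl untouched, so it offers no direct guide. Compound 1 and compound 2 do carry ethoxycarbonyl, but they also differ from compound 4 elsewhere, so their higher numbers cannot be credited to that group alone. With so small an addition, no step beyond the scatter is expected in this assay, though a slight rise is thought more likely than a fall. The expected change is a 1.4-fold higher number from compound 3 to compound 4 (0.13 log units; within the scatter). For compound 4 the estimate is 1000 nM, with an expected range from 350 nM to 3000 nM.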

Compound 4, concentration for 50% growth inhibition: 4710 nM
For compound 4 the middle estimate is 4.7-fold (0.67 log units) below the measured one, outside the stated range (above it).
By their numbers in this assay, from the lowest: compound 3; then compounds 2, 4 and 1 (each within the scatter of the next, the first and the last beyond it).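

In this assay, the change from methoxycarbonyl to ethoxycarbonyl is the only difference between the two compounds, and the step is a 6.4-fold higher number from compound 3 to compound 4 (0.80 log units; beyond the scatter) and therefore beyond the usual scatter; this shows that one added methyl at this position can matter, which the earlier step, with ethoxycarbonyl left untouched, could not show. With ethoxycarbonyl held in place, the other two steps are a 1.8-fold higher number from compound 2 to compound 4 (0.25 log units; within the scatter) for 3-hydroxyphenyl in place of 4-methoxyphenyl and a 1.9-fold lower number from compound 1 to compound 4 (0.29 log units; within the scatter) for hydrogen in place of methyl on an oxygen on an aromatic ring, so neither change separates these compounds beyond the scatter. Nothing available here explains the effect of the added methyl.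

The compounds shown leave open whether a longer chain, such as propyl, would weaken growth inhibition further, and how a carboxylic acid or an amide would compare with these esters at the same place. They also leave open whether the same methyl step would be seen with 3-methoxyphenyl or 4-methoxyphenyl in place of 3-hydroxyphenyl.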